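Methoxy to (Methylamino)methyl on the Outer Ring

A few compounds are considered here, and "the series" means these few. Any claim that something is new, unique, unknown or untested is made for them only; others in the source may bear on it.

Compound 1, `CC[C@H](C)[C@H](N)CN(C(=O)[C@@H]1C[C@H]1c1cccc(C#N)c1)c1ccc(-c2ccccc2)cc1`, gives 1600 nM in a functional assay for agonist activity at G protein-coupled receptor 88 (Homo sapiens), read by HTRF and cAMP accumulation; a higher number here means that more compound is needed for the effect, a lower number that less compound is needed. Compound 2, `COc1ccc(-c2ccc(N(C[C@@H](N)CC(C)C)C(=O)[C@@H]3C[C@H]3c3ccccc3)cc2)cc1`, gives 330 nM. Compound 3, `CC[C@H](C)[C@H](N)CN(C(=O)[C@@H]1C[C@H]1c1ccccc1)c1ccc(-c2ccc(OC)cc2)cc1`, gives 120 nM.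

Compound 3 has the lowest number of the three in this assay: the change a 2.8-fold lower number from compound 2 to compound 3 (0.44 log units; beyond the scatter) is modest, while the values of compound 1 and compound 3 lie far apart. Compound 4, `CC[C@H](C)[C@H](N)CN(C(=O)[C@@H]1C[C@H]1c1ccccc1)c1ccc(-c2ccc(CNC)cc2)cc1`, differs from compound 3 only in (methylamino)methyl in place of methoxy on an aromatic carbon. Going by the values given here, no measured step touches this outer ring, so nothing here tells how the exchange will turn out; with no guide, the expected change is no change at the digits printed from compound 3 to compound 4 (within the scatter), within the scatter. Compound 4 is therefore estimated at 120 nM, between 40 nM and 400 nM.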

Compound 4, half-maximal effective concentration: 6400 nM
For compound 4 the middle estimate is 53-fold (1.73 log units) below the measured one; measured number above the stated range.
By their numbers in this assay, from the lowest: compound 3; then compound 2; then compound 1; then compound 4.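

This outer-ring position is far from indifferent to what it carries: in this assay, (methylamino)methyl in place of methoxy gives a 53-fold higher number from compound 3 to compound 4 (1.73 log units; beyond the scatter). Going by these compounds alone, one exchange on this aromatic carbon is enough for a large step, whereas the only earlier step, on the saturated chain, was modest. Nothing measured here explains the size of this step.

The compounds shown leave open which part of the entering group matters: its nitrogen, its methyl or its extra carbon. A hydroxymethyl or an aminomethyl group on the same carbon would help separate these.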